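The compounds below may be only part of what the source reports. "The series", "measured", "known", "first", "only" and "open" are said of these compounds alone.

In a functional assay on U-937 cells (Homo sapiens) for cytotoxicity, read by MTT assay, with a stated time of 24 h (on this read-out higher numbers stand for weaker inhibition and lower numbers for stronger inhibition), compound 3 `Cc1cccc(-c2nnc(SCCCN3CCN(c4ccccn4)CC3)[nH]2)c1` gives 52300 nM, the lowest of the two numbers shown. Compound 1 `Cc1ccc(-c2nnc(SCCCN3CCN(c4cccc(Cl)c4)CC3)[nH]2)cc1` gives 257000 nM in this assay. Compound 2 `Cc1cccc(-c2nnc(SCCCN3CCN(c4ccccc4)CC3)[nH]2)c1` reaches only a limit of this assay, > 300000 nM. Among the compounds with values here, the single measured step, an at least 5.7-fold lower number from compound 2 to compound 3 (0.75 log units; beyond the scatter), concerns the group on the piperazine nitrogen and rests on (the limit of > 300000 nM in this assay, at which 1 of the 3 values shown sits).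

Compound 4 `c1ccc(Cc2nnc(SCCCN3CCN(c4ccccn4)CC3)[nH]2)cc1` differs from compound 3 by benzyl in place of 3-methylphenyl on an aromatic carbon. Within the data shown here, no measured step touches this part of the shared core, so no step beyond the scatter is expected from the change, a 1.1-fold higher number from compound 3 to compound 4 (0.06 log units; within the scatter). Compound 4 is therefore estimated at 60000 nM in this assay, with a range from 20000 nM to 200000 nM.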

Compound 4, half-maximal inhibitory concentration: 163000 nM
For compound 4 the middle estimate is 2.7-fold (0.43 log units) below the measured one; low and high end bracket the measured number.
By their numbers in this assay, from the lowest: compound 3; then compounds 4 and 1 (each within the scatter of the next). At a limit, above all of these: compound 2.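

In this assay, within the data shown here, this is the first step read at this aromatic carbon of the five-membered aromatic ring, and the change counts here: the result is a 3.1-fold higher number from compound 3 to compound 4 (0.49 log units; beyond the scatter) for a swap that keeps the same heavy-atom count and the same six-membered aromatic ring of carbon only. So at this position, the two groups are not interchangeable, even though they are built from the same atoms. Nothing shown accounts for the difference. The compounds shown leave open how an unsubstituted phenyl or a 2-phenylethyl group would read at this carbon.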